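Cytotoxicity of the aryl hydrazone series: nitro for amino

The source may report more compounds than this note shows. Statements on the series, on what has been measured and on what is new or still open speak of the compounds shown alone.

Of the compounds shown here, three have been tested in an ADME assay on J774 cells (Mus musculus, strain BALB/c) for cytotoxicity, read by resazurin assay, with a stated time of 72 h; a lower number here means that less compound is tolerated, a higher number that more compound is tolerated. Compound 1 `CC(/C=N/Nc1ccc([N+](=O)[O-])cc1)=N\NC(=O)c1ccccc1Cl` gives only a limit in this assay, > 100000 nM. Compound 2 `CC(/C=N/Nc1ccc([N+](=O)[O-])cc1)=N\NC(=O)c1ccc(C(C)(C)C)cc1` likewise gives only a limit in this assay, > 100000 nM. Among the measured compounds shown here, compound 3 `CC(/C=N/Nc1ccc([N+](=O)[O-])cc1)=N\NC(=O)c1ccccc1N` is the one member with a number in this assay, 29800 nM, so it stands alone below the other two. For the measured compounds named here, the single measured step, an at least 3.3-fold lower number from compound 1 to compound 3 (0.52 log units; beyond the scatter), is the only guide to how a change on the benzoyl ring moves this read-out, and it shows that the amino group is tied to the lower number, as against (the limit of > 100000 nM in this assay, at which 2 of the 3 values shown sit).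

Compound 4 `CC(/C=N/Nc1ccc([N+](=O)[O-])cc1)=N\NC(=O)c1ccc([N+](=O)[O-])cc1` carries the change (4-nitrophenyl in place of 2-aminophenyl on a carbonyl carbon). This removes the amino group that separated compound 3 from the limit-bound compounds 1 and 2, and puts in its place a substituent that, like chloro and tert-butyl, carries no hydrogen-bond donor. The step from compound 1 to compound 3 therefore bears on it in reverse: a return toward the limit is expected, that is a higher number in this assay, with a fair chance that only a limit is read. The step is expected to run a 3.0-fold higher number from compound 3 to compound 4 (0.48 log units; beyond the scatter). Compound 4 is expected at 90000 nM, within 30000 nM to 250000 nM.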

Compound 4, half-maximal cytotoxic concentration: > 100000 nM
Compound 4: a limit, no number; the forecaster's own chance of this, stated with the estimate: 60%; middle value at least 1.1-fold (0.04 log units) from the limit.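

With 4-nitrophenyl in place of 2-aminophenyl on the carbonyl carbon, this assay shows an at least 3.3-fold higher number from compound 3 to compound 4 (0.52 log units; beyond the scatter), so this position now has a second replacement for the 2-aminophenyl group that leaves no measurable number. Among the four compounds, the lower number goes with the 2-aminophenyl group of compound 3 alone; chloro, tert-butyl and nitro all fall on the same side of it, and no compound shown goes against this: the limit of > 100000 nM in this assay, at which 3 of the 4 values shown sit.

The steps from compound 1 and from compound 2 to compound 4 cannot be read, as each joins two limits, so nothing orders the three compounds among themselves. The compounds shown leave open whether the lower number belongs to the amino group as such, which a dimethylamino or a hydroxyl group in its place on the benzoyl ring would help to separate, and whether an aminomethyl group would carry it too. From the compounds shown here alone, how far compounds 1, 2 and 4 lie beyond the limit in this assay also stays open.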